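Replacing an Aromatic Ring with a Saturated One

A few compounds are considered here, and "the series" means these few. Any claim that something is new, unique, unknown or untested is made for them only; others in the source may bear on it.

Measured compounds:
- compound 1, `CCCNC(=O)/N=C(\N)NCCCc1sc(N)nc1C`: 178 nM
- compound 2, `Cc1nc(N)sc1CCCN/C(N)=N/C(=O)NCc1ccccc1`: 28.8 nM
- compound 3, `Cc1nc(N)sc1CCCN/C(N)=N/C(=O)Nc1ccccc1`: 525 nM

All three compounds share a core that ends in an amide-type nitrogen, and they differ only in what hangs on that nitrogen. In a functional assay on membranes from Sf9 cells for agonist activity at histamine H2 receptor (Homo sapiens), read by scintillation counting and GTPgammaS binding, with a stated time of 90 min (on this read-out lower numbers stand for an effect already at smaller amounts and higher numbers for an effect only at larger amounts of compound), compound 3 gives the highest number of the three: a 2.9-fold higher number from compound 1 to compound 3 (0.47 log units; beyond the scatter), and an 18-fold higher number from compound 2 to compound 3 (1.26 log units; beyond the scatter). Both steps lie beyond the usual scatter, so compound 3 is the weakest of the measured set on this read-out.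

The next compound, compound 4 `Cc1nc(N)sc1CCCN/C(N)=N/C(=O)NC1CCCCC1`, keeps everything in compound 3 except one change: cyclohexyl in place of phenyl on an amide-type nitrogen.

Within the data shown here, two measured steps bear on this. Going from propyl to phenyl on that nitrogen raised the number (a 2.9-fold higher number from compound 1 to compound 3 (0.47 log units; beyond the scatter)), and going from benzyl to phenyl raised it further (an 18-fold higher number from compound 2 to compound 3 (1.26 log units; beyond the scatter)). In both, a phenyl sitting directly on the amide-type nitrogen gave a higher number than a saturated group there. Cyclohexyl is a saturated six-membered ring, so the expectation is that compound 4 returns toward the numbers of compound 1 and compound 2, with a 4.8-fold lower number from compound 3 to compound 4 (0.68 log units; beyond the scatter). The estimate for compound 4 in this assay is 110 nM, within a range from 30 nM to 400 nM.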

Compound 4, half-maximal effective concentration: 148 nM
Estimate against measurement, compound 4: 1.3-fold (0.13 log units) below; the measured number falls inside the stated range.
By their numbers in this assay, from the lowest: compound 2; then compounds 4 and 1 (each within the scatter of the next); then compound 3.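

Phenyl and cyclohexyl carry the same count of heavy atoms, so the change from aromatic to non-aromatic ring on this amide-type nitrogen is enough on its own to shift the result in this assay (a 3.5-fold lower number from compound 3 to compound 4 (0.55 log units; beyond the scatter)). Cyclohexyl and propyl cannot be told apart here (a 1.2-fold lower number from compound 1 to compound 4 (0.08 log units; within the scatter)), so a saturated ring offers no visible gain over an open propyl chain, while benzyl keeps a clear edge over cyclohexyl (a 5.1-fold higher number from compound 2 to compound 4 (0.71 log units; beyond the scatter)). Compound 2 carries its phenyl on a saturated chain carbon and has the lowest number of the set, so the high number of compound 3 goes with a phenyl sitting directly on the nitrogen rather than with an aromatic ring as such, and no measurement offered here explains why.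

The compounds shown leave open whether the edge of benzyl depends on its aromatic ring or on the extra carbon that separates the ring from the nitrogen. A cyclohexylmethyl group would separate these two possibilities, and a longer chain such as phenylethyl would show whether moving the ring further out continues the trend.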